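Aryl hydrazone swap on the shared core

This account rests on a few compounds, and the source may have more. Where it says the series, first, only, none or still open, it means among the compounds named here.

Compound 3 `COc1ccc(/C=N/NC(=O)Nc2ccc(Oc3ccnc4cc(OCCCN5CCC(C)CC5)c(OC)cc34)c(F)c2)cc1` sits second highest of the three numbers in a functional assay on HT-29 cells (Homo sapiens) for cytotoxicity, read by MTT assay, with a stated time of 72 h (a higher number here means a weaker inhibitor, a lower number a stronger inhibitor), where compound 3 gives 610 nM. Its nearest neighbour is compound 2 `COc1ccc(/C=N/NC(=O)Nc2ccc(Oc3ccnc4cc(OCCCN5CCCCC5)c(OC)cc34)c(F)c2)cc1`, which gives 590 nM; the step of a 1.0-fold higher number from compound 2 to compound 3 (0.01 log units; within the scatter) lies within the scatter. Compound 1 `COc1cc2c(Oc3ccc(NC(=O)N/N=C/c4ccc(C(F)(F)F)cc4)cc3F)ccnc2cc1OCCCN1CCCC1` gives 810 nM, also within the scatter of compound 3. Compound 4 `COc1cc2c(Oc3ccc(NC(=O)N/N=C/c4ccc(Cl)cc4Cl)cc3F)ccnc2cc1OCCCN1CCC(C)CC1` is not yet measured; it differs from compound 3 by 2,4-dichlorophenyl in place of 4-methoxyphenyl on a carbon with a double bond to nitrogen. Among the compounds with values here, no single-point step touches this position: the one measured step concerns the saturated ring, and compound 1 differs from compound 2 in two places, so their two values show only that a trifluoromethyl-bearing aryl and a methoxy-bearing aryl land within the scatter of each other. On that basis compound 4 is expected to give 600 nM (range 250 nM to 1500 nM). The step of a 1.0-fold lower number from compound 3 to compound 4 (0.01 log units; within the scatter) is estimated to stay within the scatter.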

Compound 4, half-maximal inhibitory concentration: 470 nM
Beside the measured number, compound 4's estimate is 1.3-fold (0.11 log units) above it, within the range that was stated.
By their numbers in this assay, from the lowest: compounds 4, 2, 3 and 1 (each within the scatter of the next).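

In this assay, the group on the carbon with a double bond to nitrogen now has its first single-place reading: a 1.3-fold lower number from compound 3 to compound 4 (0.11 log units; within the scatter), for 2,4-dichlorophenyl in place of 4-methoxyphenyl. This position therefore tolerates the exchange of a hydrogen-bond acceptor-bearing aryl for one with two chlorines, with no change readable beyond the scatter. No measured evidence bears on the reason for this result. Still open, on these data alone, is whether an aryl carrying an amine or a carboxylic acid at this carbon would move the number beyond the scatter.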